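Urea-to-amide change on the shared core

This account rests on a few compounds, and the source may have more. Where it says the series, first, only, none or still open, it means among the compounds named here.

Three members of the series have been measured in a functional assay on NCI-H522 cells (Homo sapiens) for inhibition, read by sulforhodamine B assay, with a stated time of 48 h, tested at 10 uM; a higher number here means a weaker effect of the compound at the concentration tested, a lower number a stronger effect. Compound 3 `COc1cc(Cl)cc(-c2nn(-c3cccc(NC(=O)Nc4ccc(Cl)c(Cl)c4)c3)cc2-c2ccncc2)c1` gives -19% in this assay, the lowest of the three numbers. Compound 1 `O=C(Nc1cccc(-n2cc(-c3ccncc3)c(-c3cc(O)cc(Cl)c3)n2)c1)Nc1ccc(Cl)c(C(F)(F)F)c1` gives -16% in this assay, and compound 2 `COc1cc(Cl)cc(-c2nn(-c3cccc(NC(=O)Nc4cc(C(F)(F)F)cc(C(F)(F)F)c4)c3)cc2-c2ccncc2)c1` gives -15.6% in this assay. Both of these stand within the usual scatter of the value of compound 3, so the three numbers cannot be told apart, and none of the three compounds can be called stronger or weaker than another on this evidence.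

Compound 4 `COc1cc(Cl)cc(-c2nn(-c3cccc(NC(=O)c4cccc(C(F)(F)F)c4)c3)cc2-c2ccncc2)c1` is not yet measured. It differs from compound 3 in a single place: 3-(trifluoromethyl)phenyl in place of (3,4-dichlorophenyl)amino on a carbonyl carbon. Cut one bond further out, the change reads (3,4-dichlorophenyl)carbamoyl to (3-(trifluoromethyl)phenyl)carbonyl, so the urea of compound 3 becomes an amide in compound 4.

Going by the values given here, no measured pair differs in one place, so no step size is available as a guide. The three measured values lie close together despite different groups on the urea, and the expected step from compound 3 to compound 4 is a number 7 percentage points higher from compound 3 to compound 4 (within the scatter), without a clear direction and not beyond the scatter. Compound 4 is therefore expected to give -12% in this assay, estimated within -35% to 12%.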

Compound 4, a percentage reported as activity, at one concentration (the size of the read-out at that concentration, not a potency): 32.2%
For compound 4 the middle estimate is 44.2 percentage points below the measured one, outside the stated range (above it).
By their numbers in this assay, from the lowest: compounds 3, 1 and 2 (each within the scatter of the next); then compound 4.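

Working from the carbonyl carbon, replacing (3,4-dichlorophenyl)amino with 3-(trifluoromethyl)phenyl gives a number 51.2 percentage points higher from compound 3 to compound 4 (beyond the scatter) in this assay, so this position is not indifferent to change, and the effect of compound 3 at the concentration tested is largely lost in compound 4. The three ureas gave no sign of this, since their numbers stand within the scatter of one another despite their different groups, and compound 4, the only amide shown, is the first compound to separate from them. The change also removes the hydrogen-bond donor counted on the leaving group, but nothing measured here ties the step to that loss or to any other feature of the change.

The step joins two differences in one change, the urea becoming an amide and the aryl group being replaced, and the compounds shown do not separate them. An amide with 3,4-dichlorophenyl on the carbonyl carbon and a urea with 3-(trifluoromethyl)phenyl would divide the step between them, and a carbamate, with an oxygen atom in place of the urea nitrogen, would test that nitrogen directly.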